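Extending the amide chain of a benzofuran amide

The compounds below may be only part of what the source reports. "The series", "measured", "known", "first", "only" and "open" are said of these compounds alone.

Measured so far:
compound 1, `CCCCCCCCCCCCNC(=O)[C@@H](NC(=O)c1cc2ccccc2o1)[C@@H](C)O`: 20900 nM
compound 2, `CCCCCCCCCCCCNC(=O)[C@@H](NC(=O)/C=C/c1ccccc1)[C@@H](C)O`: > 200000 nM

Within the data shown here, compound 1 is the only compound with a finished number in a functional assay on MCF7 cells (Homo sapiens) for cytotoxicity, read by MTT assay, with a stated time of 48 h; a lower number here means a stronger inhibitor, a higher number a weaker inhibitor; in this assay compound 1 gives 20900 nM. Compound 2 reached only a limit of the assay, (the limit of > 200000 nM in this assay, at which 1 of the 2 values shown sits), so for compound 2 the reading > 200000 nM is a limit and not a number. Among the measured compounds shown here, the one measured step, an at least 9.5-fold higher number from compound 1 to compound 2 (0.98 log units; beyond the scatter), concerns the group on the carbonyl carbon and does not touch the chain that is changed here.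

Compound 3, `CCCCCCCCCCCCCCCCCCNC(=O)[C@@H](NC(=O)c1cc2ccccc2o1)[C@@H](C)O`, differs from compound 1 by hexyl in place of hydrogen on a saturated chain carbon, ten or more bonds along the chain from an amide-type nitrogen. For the measured compounds named here, no measured step bears on that change, so nothing in the data points to a shift in either direction. The step of a 1.2-fold higher number from compound 1 to compound 3 (0.08 log units; within the scatter) is therefore expected to stay within the usual scatter. Compound 3 is estimated at 25000 nM, with a range from 8000 nM to 80000 nM.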

Compound 3, half-maximal inhibitory concentration: 126000 nM
The estimate for compound 3 lay 5.0-fold (0.70 log units) below the measured number; the measured number lies above the stated range.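

The far part of the amide chain turns out to matter: in this assay, hexyl in place of hydrogen on a saturated chain carbon, ten or more bonds along the chain from an amide-type nitrogen, gives a 6.0-fold higher number from compound 1 to compound 3 (0.78 log units; beyond the scatter), so the longer chain makes the weaker inhibitor here. Among these compounds, the one earlier step concerned the group on the carbonyl carbon, so this is the first measured sign that the chain also affects the number, even this far along it. Nothing measured in these data accounts for this step.

Among the compounds shown here, two chain lengths give only one step, so they cannot tell whether the number rises steadily with length or jumps at some point. A shorter chain, or a chain carrying an amine or a carboxylic acid, remains an open case.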